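The source may hold more compounds than are shown below. What is called first, only, known or untested is meant among the compounds shown, and "the series" means these compounds.

Measured so far:
- compound 1, `CCCCNC(=O)N1CC1C#N`. In a functional assay on MCF7 cells (Homo sapiens) for inhibition (a higher number here means a weaker inhibitor, a lower number a stronger inhibitor), compound 1 gives > 12000 nM, which is a limit of the assay rather than a number.
- compound 2, `CNC(=O)N1CC1C#N`. Compound 2 gives 18000 nM.
- compound 3, `N#CC1CN1C(=O)NC1CCCCC1`. Compound 3 gives 9800 nM.

Of the two readable numbers, compound 2 stands highest, with compound 3 nearest; the gap between them lies within the usual scatter, so the two cannot be told apart. Compound 4, `CC(C)(C)NC(=O)N1CC1C#N`, is the compound still to be measured. It differs from compound 2 by tert-butyl in place of methyl on an amide-type nitrogen.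

Within the data shown here, only one measured step changes the group on this nitrogen: a step that the limit leaves unreadable from compound 1 to compound 2, and its size cannot be read because of the limit of > 12000 nM in this assay, at which 1 of the 3 values shown sits. Compounds 2 and 3 carry different groups on the same nitrogen and their values stay within the scatter. Nothing measured here points to a change in either direction, so no step beyond the scatter is expected. Compound 4 is therefore expected to give 15000 nM, in a range from 6000 nM to 40000 nM. The expected step of a 1.2-fold lower number from compound 2 to compound 4 (0.08 log units; within the scatter) is accordingly close to none.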

Compound 4, half-maximal inhibitory concentration: 120000 nM
The estimate for compound 4 lay 8.0-fold (0.90 log units) below the measured number; the whole stated range lies below it.
By their numbers in this assay, from the lowest: compounds 3 and 2 (each within the scatter of the next); then compound 4.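

Among these compounds, changing this group can clearly move the number: in this assay, tert-butyl in place of methyl on the amide-type nitrogen gives a 6.7-fold higher number from compound 2 to compound 4 (0.82 log units; beyond the scatter), the first readable step at this position that lies beyond the scatter. More carbon alone does not account for the change, since compound 3, which carries cyclohexyl, gives 9800 nM, while compound 4 gives 120000 nM. The steps involving compound 1 cannot be read, since its value is a limit: the limit of > 12000 nM in this assay, at which 1 of the 4 values shown sits.

As far as these compounds go, it remains open how a flat ring such as phenyl, or a chain ending in an amine or a carboxylic acid, would behave on this nitrogen. The compounds shown also leave open whether isopropyl, which lies between methyl and tert-butyl in branching, would give a number nearer compound 2 or compound 4.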